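Trading sulfur for oxygen at compound 2

A few compounds are considered here, and "the series" means these few. Any claim that something is new, unique, unknown or untested is made for them only; others in the source may bear on it.

In an ADME assay on HEK-293T cells (Homo sapiens) for cytotoxicity, read by CCK-8 assay, with a stated time of 48 h (on this read-out lower numbers stand for stronger inhibition and higher numbers for weaker inhibition), compound 1 `COc1ccc(NC(=S)NCCNS(=O)(=O)c2sccc2-c2ccc(C)cc2Oc2ccc(O)c(O)c2)cc1` reads > 20000 nM as a limit of the assay, not a number. For the measured compounds named here, compound 2 `Cc1ccc(-c2ccsc2S(=O)(=O)NCCNC(=S)Nc2cccc([N+](=O)[O-])c2)c(Oc2ccc(O)c(O)c2)c1` gives 7900 nM as the only true number so far. The change to compound 3 `Cc1ccc(-c2ccsc2S(=O)(=O)NCCNC(=O)Nc2cccc([N+](=O)[O-])c2)c(Oc2ccc(O)c(O)c2)c1` is this: a group of 12 heavy atoms (7 carbon, 2 nitrogen, 3 oxygen; one six-membered aromatic ring of carbon only) in place of a group of 12 heavy atoms (7 carbon, 2 nitrogen, 2 oxygen, 1 sulfur; one six-membered aromatic ring of carbon only), on an amine nitrogen. Going by the values given here, the one measured step of an at least 2.5-fold lower number from compound 1 to compound 2 (0.40 log units; beyond the scatter) lies at another place on the molecule, so it offers only a rough sense of size. The expected step is a 1.3-fold higher number from compound 2 to compound 3 (0.10 log units; within the scatter) with no change beyond the scatter. Compound 3 is expected at 10000 nM with a range of 4500 nM to 20000 nM as the estimate.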

Compound 3, half-maximal inhibitory concentration: 6800 nM
Compound 3: middle estimate off by 1.5-fold (0.17 log units), on the high side; low and high end bracket the measured number.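

In this assay, the (3-nitrophenyl)carbamoyl group on the amine nitrogen, with oxygen in place of sulfur, brings a 1.2-fold lower number from compound 2 to compound 3 (0.07 log units; within the scatter), so this exchange leaves the reading unchanged within the scatter. The wider step, an at least 2.9-fold lower number from compound 1 to compound 3 (0.46 log units; beyond the scatter), stays beyond the scatter. That step has an open end, since compound 1 reads only as a limit of the assay: the limit of > 20000 nM in this assay, at which 1 of the 3 values shown sits.

On these data alone, what an amine or a nitrile in place of the nitro group would read stays open. So does whether the same exchange behaves alike alongside the 4-methoxyphenyl group of compound 1.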